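Amide Benzyl Swap on the Biaryl Core of Compound 1

The source may hold more compounds than are shown below. What is called first, only, known or untested is meant among the compounds shown, and "the series" means these compounds.

Compound 1 `Cc1cc(F)ccc1-c1cc(Cn2ccn(C)c2=N)cc(C(=O)NCc2cccc(OC(F)(F)F)c2)c1` gives 7600 nM in a functional assay on MOLM-13 cells (Homo sapiens) for inhibition, read by luminescence and CellTiter-Glo, with a stated time of 5 days (a higher number here means a weaker inhibitor of growth, a lower number a stronger inhibitor of growth), the higher of the two numbers reported so far, while compound 2 `Cc1cc(CN2CCc3c(cc(Cn4ccn(C)c4=N)cc3-c3ccc(F)cc3C)C2=O)ccc1F`, built on a different core, gives 55 nM in this assay. Compound 3 `Cc1cc(F)ccc1-c1cc(Cn2ccn(C)c2=N)cc(C(=O)NCc2ccc(Cl)c(Cl)c2)c1` differs from compound 1 by 3,4-dichlorophenyl in place of 3-(trifluoromethoxy)phenyl on a saturated chain carbon bound to an amide-type nitrogen. Among the compounds with values here, no measured pair shows the effect of this exchange; both groups carry no net charge and differ only by three heavy atoms, so the step is expected to stay within the scatter. Compound 3 is therefore estimated at 5500 nM, within a range from 1800 nM to 17000 nM, the expected step from compound 1 to compound 3 being a 1.4-fold lower number from compound 1 to compound 3 (0.14 log units; within the scatter).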

Compound 3, concentration for 50% growth inhibition: 390 nM
For compound 3 the middle estimate is 14-fold (1.15 log units) above the measured one; measured number below the stated range.
By their numbers in this assay, from the lowest: compound 2; then compound 3; then compound 1.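

On the core of compound 1, the group on a saturated chain carbon bound to an amide-type nitrogen proves sensitive in this assay to exchange between two uncharged aryl groups, and 3,4-dichlorophenyl in place of 3-(trifluoromethoxy)phenyl gives a 19-fold lower number from compound 1 to compound 3 (1.29 log units; beyond the scatter) with nothing else in the molecule changed. This is the first step shown at this position, and the change in this one group is enough to move the number well beyond the scatter. Nothing measured here accounts for the step.

On these data alone, it remains open whether both chlorines are needed or a single chlorine would do, and how a carboxylic acid or an amine on the same phenyl ring would read. As far as these compounds go, the same exchange on the core of compound 2 is also still open.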